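Methylsulfanyl in place of methoxy on the shared core

The source may hold more compounds than are shown below. What is called first, only, known or untested is meant among the compounds shown, and "the series" means these compounds.

Compound 1 `COc1ncnc2c1c(-c1ccsc1)cn2[C@@H]1O[C@H](CO)[C@@H](O)[C@H]1O` is the reference point of the set. In a functional assay on CEM-DNR-bulk cells (Homo sapiens), read by MTT assay, with a stated time of 72 h (on this read-out higher numbers stand for weaker inhibition and lower numbers for stronger inhibition), compound 1 gives 7640 nM, the lowest of the two numbers in hand. Compound 2 `COc1ncnc2c1c(-c1cccs1)cn2[C@@H]1O[C@H](CO)[C@@H](O)[C@H]1O` differs only by thiophen-2-yl in place of thiophen-3-yl; in this assay compound 2 gives 12100 nM, and the step of a 1.6-fold higher number from compound 1 to compound 2 (0.20 log units; within the scatter) does not separate the two. Compound 3 `COc1ncnc2c1c(I)cn2[C@@H]1O[C@H](CO)[C@@H](O)[C@H]1O` carries iodo in place of the thiophene. For compound 3 the read-out is a limit, > 20000 nM, as noted in the limit of > 20000 nM in this assay, at which 1 of the 3 values shown sits. Against compound 1 the step of an at least 2.6-fold higher number from compound 1 to compound 3 (0.41 log units; beyond the scatter) is the only one that clears the scatter, while an at least 1.6-fold higher number from compound 2 to compound 3 (0.21 log units; that floor lies within the scatter) does not.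

Compound 4 `CSc1ncnc2c1c(-c1ccsc1)cn2[C@@H]1O[C@H](CO)[C@@H](O)[C@H]1O` keeps the thiophen-3-yl of compound 1 and alters a different position: methylsulfanyl in place of methoxy on an aromatic carbon. None of the three measured steps touches the methoxy; all of them exchange the group on the five-membered ring, so they bear on compound 4 only indirectly, through the shared thiophen-3-yl with compound 1. Among the compounds with values here, no measured step therefore predicts a move beyond the scatter, and the estimated step of a 1.0-fold higher number from compound 1 to compound 4 (0.02 log units; within the scatter) in this assay is set at no change. Compound 4 is expected to give 8000 nM in this assay, within 3000 nM to 20000 nM.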

Compound 4, half-maximal inhibitory concentration: > 20000 nM
Compound 4: no number, only a limit; the forecaster's own chance of this, stated with the estimate: 12%; at least 2.5-fold (0.39 log units) between middle value and limit.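

In this assay, methylsulfanyl in place of methoxy gives an at least 2.6-fold higher number from compound 1 to compound 4 (0.41 log units; beyond the scatter), so this is the first step shown that changes something other than the thiophene or iodo group, and it clears the scatter. The change sits on an aromatic carbon of a six-membered aromatic ring with 2 nitrogen, and the counted features stay the same: heavy atoms, hydrogen-bond donors and hydrogen-bond acceptors match, with sulfur replacing oxygen, yet this exchange alone is enough to move the read-out beyond the scatter. Compound 4 gives only a limit, > 20000 nM, so the step has a floor but no upper end: the limit of > 20000 nM in this assay, at which 2 of the 4 values shown sit.

The compounds shown leave open how an amine, an ethoxy group or a longer alkoxy chain at this place would read against compound 1, and so whether the methoxy itself is preferred or only the methylsulfanyl is poorly tolerated. They also leave open whether the methylsulfanyl step holds with thiophen-2-yl or iodo in place of thiophen-3-yl, and what number compound 4 would give if it could be read beyond the limit.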